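A few compounds are considered here, and "the series" means these few. Any claim that something is new, unique, unknown or untested is made for them only; others in the source may bear on it.

In a physicochemical assay for lipophilicity, using the shake flask method, measured as octanol-water partition, with a stated time of 30 min, at pH 7.4 (a lower number here means a more polar compound, a higher number a more lipophilic compound), compound 1 `Cc1ccccc1-c1nc2cn(-c3cccc(C#N)c3)nc2c(=O)n1CC1CCCN(C(C)C)C1` gives 1.8 and lies within the scatter of compound 3 `Cc1ncccc1-c1nc2cn(-c3ccccc3)nc2c(=O)n1C[C@H]1CCCN(C[C@H]2CCCO2)C1` at 1.7 while compound 2 `Cc1ncccc1-c1nc2cn(-c3cccc(OC(C)C)c3)nc2c(=O)n1C[C@H]1CCCN(C[C@H]2CCCO2)C1` stands at 2.7 on the same scale, beyond the scatter from compound 1. The step followed here leads to compound 4 `COc1cccc(-n2cc3nc(-c4ccccc4C)n(CC4CCCN(C(C)C)C4)c(=O)c3n2)c1` through a single change methoxy in place of cyano on an aromatic carbon that puts methoxy in place of cyano on an aromatic carbon, meta to a large group. Among the measured compounds shown here, no measured pair compares these two groups directly. The nearest evidence is a number 1.00 log units lower from compound 2 to compound 3 (beyond the scatter) when hydrogen replaces isopropoxy on an aromatic carbon, a modest step beyond the scatter. It involves neither cyano nor methoxy, so it is only a loose guide, and a smaller, upward move in this assay is expected here. The expected size is a number 0.40 log units higher from compound 1 to compound 4 (beyond the scatter) on this estimate. Compound 4 is therefore estimated at 2.2 with an expected range from 1.8 to 2.6 around that figure.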

Compound 4, distribution coefficient: 2.5
For compound 4 the middle estimate is 0.30 log units below the measured one; the measured number falls inside the stated range.
By their numbers in this assay, from the lowest: compounds 3 and 1 (each within the scatter of the next); then compounds 4 and 2 (each within the scatter of the next).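

In this assay, replacing 3-cyanophenyl with 3-methoxyphenyl gives a number 0.70 log units higher from compound 1 to compound 4 (beyond the scatter), so the exchange at this aromatic carbon, meta to a large group, moves the number even though each group has 2 heavy atoms and 1 hydrogen-bond acceptor. This is the first direct comparison of cyano and methoxy among the compounds shown, since the earlier step, a number 1.00 log units lower from compound 2 to compound 3 (beyond the scatter), involves neither group. Nothing measured here explains the size of the new step. The compounds shown leave open what a chlorine, a primary amine or a carboxylic acid would give on this same aromatic carbon. They also leave open whether cyano and methoxy would stand the same distance apart with the other side groups of compound 2.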